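A few compounds are considered here, and "the series" means these few. Any claim that something is new, unique, unknown or untested is made for them only; others in the source may bear on it.

Compound 1 `O=C(O)CCNC(=O)c1ccc(C(Oc2ccc(-n3cc(C(F)(F)F)cn3)cc2)C2CCC2)cc1`: 26 mL/min/kg
Compound 2 `O=C(O)CCNC(=O)c1ccc(C(Oc2ccc(-n3cc(C(F)(F)F)cn3)cc2)C2CCCC2)cc1`: 22 mL/min/kg

In an ADME assay on microsomes from liver (Homo sapiens) for metabolic stability (a higher number here means faster removal of the compound, a lower number slower removal), compound 2 gives 22 mL/min/kg, within the scatter of compound 1. Compound 3 `CC(C)(C)C(Oc1ccc(-n2cc(C(F)(F)F)cn2)cc1)c1ccc(C(=O)NCCC(=O)O)cc1` differs from compound 2 as follows: tert-butyl in place of cyclopentyl on a saturated chain carbon bound to an aromatic carbon and an oxygen on an aromatic ring. For the measured compounds named here, the one measured step at this place, a 1.2-fold lower number from compound 1 to compound 2 (0.07 log units; within the scatter), bears on the change only in part, as it joins two ring groups. No group without a ring has been measured here, so the range is kept wide. No step beyond the scatter is expected in this assay, in either direction. The estimated step is a 1.1-fold lower number from compound 2 to compound 3 (0.04 log units; within the scatter). For compound 3 the expected value is 20 mL/min/kg, with an estimated range of 11 mL/min/kg to 36 mL/min/kg.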

Compound 3, clearance: 31 mL/min/kg
The estimate for compound 3 lay 1.6-fold (0.19 log units) below the measured number; measured number inside the range.
By their numbers in this assay, from the lowest: compounds 2, 1 and 3 (each within the scatter of the next).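

In this assay, for the compounds shown here, tert-butyl is the first group without a ring at this place, on a saturated chain carbon bound to an aromatic carbon and an oxygen on an aromatic ring. It remains within the scatter of both ring groups (a 1.4-fold higher number from compound 2 to compound 3 (0.15 log units; within the scatter); a 1.2-fold higher number from compound 1 to compound 3 (0.08 log units; within the scatter)). Across compounds 1, 2 and 3, neither ring size nor the presence of a ring separates the numbers, and no measured evidence bears on this result.

Still open, on these data alone, is whether a smaller chain such as ethyl, a phenyl ring, or a group carrying an amine or an ether oxygen at this place would give a step beyond the scatter.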